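A Methyl on the Saturated Ring: Compound 3 Expected

The compounds below may be only part of what the source reports. "The series", "measured", "known", "first", "only" and "open" are said of these compounds alone.

Going by the values given here, compound 1 `COc1cc2c(Oc3ccc(NC(=O)c4cc(-c5cccc(Cl)c5)nc5ccccc45)cc3F)ccnc2cc1OCCCN1CCCCC1` is the only compound in this set for which a number is known. In a functional assay on U-87MG ATCC cells (Homo sapiens) for cytotoxicity, read by MTT assay, with a stated time of 72 h (a lower number here means a stronger inhibitor, a higher number a weaker inhibitor), compound 1 gives 150 nM. Compound 2 `COc1cc2c(Oc3ccc(NC(=O)c4cc(-c5ccc(Cl)c(Cl)c5)nc5ccccc45)cc3F)ccnc2cc1OCCCN1CCCCC1` gives "not determined" (no result reported) in this assay, so it offers no point of comparison.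

Compound 3 `COc1cc2c(Oc3ccc(NC(=O)c4cc(-c5cccc(Cl)c5)nc5ccccc45)cc3F)ccnc2cc1OCCCN1CCC(C)CC1` differs from compound 1 in one place: methyl in place of hydrogen on a saturated ring carbon. Among the compounds with values here, no step between two measured compounds is available, so the expectation for compound 3 rests on the small size of the change alone, methyl in place of hydrogen on a saturated ring carbon, and on the value of compound 1 in this assay, 150 nM. The author expects the step of no change at the digits printed from compound 1 to compound 3 (within the scatter) to stay within the usual scatter of repeated measurements, in no firm direction. Compound 3 is therefore estimated to give 150 nM in this assay, with a range from 60 nM to 400 nM.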

Compound 3, half-maximal inhibitory concentration: 580 nM
The estimate for compound 3 lay 3.9-fold (0.59 log units) below the measured number; the whole stated range lies below it.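

In this assay, going by these compounds alone, replacing piperidin-1-yl with 4-methylpiperidin-1-yl gives a 3.9-fold higher number from compound 1 to compound 3 (0.59 log units; beyond the scatter) in the first measured step of this set. The step shows that this position is not indifferent to substitution: a single methyl on the saturated ring carbon, three ring bonds from the ring nitrogen, is enough to give a weaker compound in these cells. No measurement shown here bears on what lies behind this difference.

The compounds shown leave open whether a hydroxyl group or an ethyl group on the same ring carbon would bring a similar step, and whether a morpholine in place of the piperidine would change the number. Within the data shown here, compound 2 has no reported result, so no step involving it can be read.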